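Swapping the benzamide aryl of compound 2

The source may report more compounds than this note shows. Statements on the series, on what has been measured and on what is new or still open speak of the compounds shown alone.

Of the compounds shown here, three have been measured in an assay on HEK293 cells for inhibition of Voltage-dependent N-type calcium channel subunit alpha-1B (Homo sapiens), read by FLIPR and calcium flux, in the presence of a further agent that is not named here; a lower number here means a stronger inhibitor, a higher number a weaker inhibitor. Compound 1 `CCCN(C1CCN(Cc2c(OC)cccc2OC)CC1)S(=O)(=O)c1cccc(C(F)(F)F)c1` gives 120 nM, compound 2 `CS(=O)(=O)c1ccc(F)cc1C(=O)N1CCC(N(C2CC2)S(=O)(=O)c2cccc(C(F)(F)F)c2)CC1` gives 560 nM, and compound 3 `CS(=O)(=O)c1ccc(F)cc1C(=O)N1CCC(N(C2CC2)S(=O)(=O)c2cc(C(F)(F)F)ccc2F)CC1` gives 2500 nM. Compound 2 thus holds the second highest of the three numbers: its nearest neighbour is compound 3, reached by a 4.5-fold higher number from compound 2 to compound 3 (0.65 log units; beyond the scatter), and its furthest is compound 1, whose lower value lies beyond the scatter.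

Compound 4 `CN(C)c1cccc(C(=O)N2CCC(N(C3CC3)S(=O)(=O)c3cccc(C(F)(F)F)c3)CC2)c1` differs from compound 2 in one place: 3-(dimethylamino)phenyl in place of 5-fluoro-2-(methylsulfonyl)phenyl on a carbonyl carbon. Going by the values given here, the only single-point step measured so far, a 4.5-fold higher number from compound 2 to compound 3 (0.65 log units; beyond the scatter), concerns a change on the sulfonamide aryl, not on the carbonyl-attached ring, so it offers no direct guide to the present change. Among the compounds with values here, compound 1 shares the sulfonamide part of compound 2 but differs in several places at once, so its value shows only that this core can reach a lower number. Within the data shown here, with no measured precedent for a change on the benzamide aryl, the author expects at most a modest step in this assay, in either direction, and most likely none beyond the scatter. Compound 4 is therefore estimated at 600 nM, within a range of 150 nM to 2500 nM, which corresponds to an expected step of a 1.1-fold higher number from compound 2 to compound 4 (0.03 log units; within the scatter).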

Compound 4, half-maximal inhibitory concentration: 240 nM
Estimate against measurement, compound 4: 2.5-fold (0.40 log units) above; the range from low to high includes it.
By their numbers in this assay, from the lowest: compounds 1 and 4 (each within the scatter of the next); then compound 2; then compound 3.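

In this assay, going by these compounds alone, replacing 5-fluoro-2-(methylsulfonyl)phenyl with 3-(dimethylamino)phenyl on the carbonyl carbon gives a 2.3-fold lower number from compound 2 to compound 4 (0.37 log units; beyond the scatter), the first measured step at this position. The earlier compounds shown here showed a change only on the sulfonamide aryl, whereas this result shows that the group on the carbonyl carbon also moves the number beyond the scatter, and that neither the fluorine nor the methylsulfonyl group of compound 2 is required for a value on this scale. Nothing shown here explains the size or direction of the step.

The exchange removes a fluoro and a methylsulfonyl group and adds a dimethylamino group in a single move, so the compounds shown cannot assign the step to any one of them, and an unsubstituted phenyl or a morpholine in place of the dimethylamino group would help to separate these contributions. From the compounds shown here alone, it also remains open whether the added aromatic fluoro behind a 4.5-fold higher number from compound 2 to compound 3 (0.65 log units; beyond the scatter) would have a comparable effect on the sulfonamide aryl of compound 4, since that step has been read only with the 5-fluoro-2-(methylsulfonyl)phenyl amide.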